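Cyclopropyl for methylsulfanyl on the shared core

The compounds below may be only part of what the source reports. "The series", "measured", "known", "first", "only" and "open" are said of these compounds alone.

Measured so far:
compound 1 `CCOC(=O)N1C[C@@H]2C[C@H]1CN2c1nc(SC)cc(-c2cnc(N)c(OC(F)F)n2)n1`, 44 nM
compound 2 `CSc1cc(-c2cnc(N)c(OC(F)F)n2)nc(N2C[C@@H]3C[C@H]2CO3)n1`, 45 nM

Both measured compounds were tested in an assay on Sf21 cells for inhibition of mitogen-activated protein kinase kinase kinase 13 (Homo sapiens), read by HTRF, with a stated time of 1.5 h; a higher number here means a weaker inhibitor, a lower number a stronger inhibitor. Compound 1 gives 44 nM and compound 2 gives 45 nM; the two numbers lie within the scatter of each other, so no order between them can be read. Among the measured compounds shown here, compound 1 thus stands level with the only other measured compound.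

The unmeasured compound 3 `CCOC(=O)N1C[C@@H]2C[C@H]1CN2c1nc(-c2cnc(N)c(OC(F)F)n2)cc(C2CC2)n1` keeps the bicyclic carbamate of compound 1 and changes one position of the core: cyclopropyl in place of methylsulfanyl on an aromatic carbon. For the measured compounds named here, no pair of measured compounds shows this replacement, so its effect on this assay is unknown from the data here.

Lacking a measured step, the estimated step is a 1.5-fold higher number from compound 1 to compound 3 (0.17 log units; within the scatter), which is a small expected change for compound 3. Compound 3 is therefore estimated at 65 nM, with a range from 20 nM to 200 nM.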

Compound 3, half-maximal inhibitory concentration: 45 nM
The estimate for compound 3 lay 1.4-fold (0.16 log units) above the measured number; the range from low to high includes it.
By their numbers in this assay, from the lowest: compounds 1, 2 and 3 (each within the scatter of the next).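

In this assay, among the compounds shown here, cyclopropyl in place of methylsulfanyl on an aromatic carbon of the shared core gives a 1.0-fold higher number from compound 1 to compound 3 (0.01 log units; within the scatter), the only step so far that can be read at this position. With the bicyclic carbamate of compound 1 kept, the sulfur is therefore not required for a number at this level: a three-membered carbon ring on the same aromatic carbon, opposite the ring nitrogen, gives a value within the scatter. No measurement at hand offers a reason for this match between the two groups.

From the compounds shown here alone, whether the same replacement gives a like result on compound 2 remains open. Also open, going by these compounds, is how an amine, a methoxy group or a longer chain such as propyl would read at this position in this assay.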